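The compounds below may be only part of what the source reports. "The series", "measured", "known", "first", "only" and "open" are said of these compounds alone.

Measured so far in a functional assay on ileum (Cavia porcellus) for antagonist activity; a lower number here means a stronger inhibitor, a higher number a weaker inhibitor:
- compound 1 `Cc1cc(OCCCOc2ccccc2)cc2oc(=O)c([N+](=O)[O-])c(O)c12` gives 5200 nM
- compound 2 `CCCc1c(OCCCOc2ccccc2)ccc2c(O)c([N+](=O)[O-])c(=O)oc12` gives 540 nM
- compound 3 `O=C(O)c1ccc(OCC(O)COc2ccc3c(O)c([N+](=O)[O-])c(=O)oc3c2)cc1` gives > 10000 nM as a limit

Compound 3 is the starting point here, and it has no true number. Its > 10000 nM is a limit of the assay and not a number.

Compound 4 `CCCc1cc(F)ccc1OCC(O)COc1ccc2c(O)c([N+](=O)[O-])c(=O)oc2c1` has not yet been measured. It differs from compound 3 in one place 4-fluoro-2-propylphenyl in place of 4-carboxyphenyl on an oxygen on a saturated carbon and has 4-fluoro-2-propylphenyl in place of 4-carboxyphenyl on an oxygen on a saturated carbon.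

Within the data shown here, no measured pair of compounds shows this change directly, so any expectation is indirect. It rests on compound 2 at 540 nM, which like compound 4 carries a propyl group, and on compound 1 at 5200 nM, and neither of them has the 4-carboxyphenyl group.

The expected move in this assay is toward stronger inhibition and beyond the usual scatter, an estimated step of an at least 10-fold lower number from compound 3 to compound 4 (1.00 log units; beyond the scatter) in size.

For compound 4 the estimate is 1000 nM with 200 nM to 6000 nM as the expected range.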

Compound 4, half-maximal inhibitory concentration: 140 nM
The estimate for compound 4 lay 7.1-fold (0.85 log units) above the measured number; measured number outside the range, below it.
By their numbers in this assay, from the lowest: compound 4; then compound 2; then compound 1. At a limit, above all of these: compound 3.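

In this assay, putting 4-fluoro-2-propylphenyl in place of 4-carboxyphenyl on this oxygen gives an at least 71-fold lower number from compound 3 to compound 4 (1.85 log units; beyond the scatter), and nothing else in the molecule changes. This is the first pair shown that differs in one place only, so it is the first direct sign that the group carried here can move the result well beyond the scatter. Compound 3 gives > 10000 nM, which is a limit of the assay and not a number, so the step marks only a minimum size: the limit of > 10000 nM in this assay, at which 1 of the 4 values shown sits.

The change removes the carboxylic acid and adds the propyl group and the fluorine all at once, so the compounds shown cannot tell which of these parts accounts for the step. On these data alone, what a phenyl ring carrying only a propyl group, only a fluorine or an amine would give at this place in this assay also remains open.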